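The source may report more compounds than this note shows. Statements on the series, on what has been measured and on what is new or still open speak of the compounds shown alone.

Compound 1 `O=C1CNC(=O)N1C[C@H]1CN(c2ccc(-n3cc(-c4ccccn4)cn3)c(F)c2)C(=O)O1`: in an ADME assay on HEK293-A cells (Homo sapiens) for cytotoxicity, read by MTT assay, with a stated time of 48 h (a higher number here means a weaker inhibitor, a lower number a stronger inhibitor), compound 1 gives > 400 ug/mL, which is a limit of the assay.
Compound 2 `O=C1O[C@@H](Cn2ccnc2)CN1c1ccc(-n2cc(-c3ccccn3)cn2)c(F)c1`: in this assay compound 2 gives > 400 ug/mL, again a limit.
Compound 3 `CS(=O)(=O)NC[C@H]1CN(c2ccc(-n3cc(-c4ccccn4)cn3)c(F)c2)C(=O)O1`: in this assay compound 3 gives 314 ug/mL.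

Within the data shown here, compound 3 thus holds the only number among the three; the other two sit at the limit of > 400 ug/mL in this assay, at which 2 of the 3 values shown sit. Compound 4 `NC(=O)[C@H]1CN(c2ccc(-n3cc(-c4ccccn4)cn3)c(F)c2)C(=O)O1` differs from compound 3 by carbamoyl in place of (methanesulfonamido)methyl on a saturated ring carbon. The measured steps that touch the same part of the shared core are an at least 1.2-fold lower number from compound 1 to compound 3 (0.10 log units; that floor lies within the scatter) and an at least 1.2-fold lower number from compound 2 to compound 3 (0.10 log units; that floor lies within the scatter), both floors that lie within the scatter, while a step that the two limits leave unreadable from compound 1 to compound 2 stays unreadable. Every exchange of the group on this side chain has so far left the read-out at or near the limit, so no step beyond the scatter is expected for compound 4, and a return to a limit is as likely as a number. Compound 4 is therefore estimated at 360 ug/mL, between 200 ug/mL and 600 ug/mL, which means an expected step of a 1.1-fold higher number from compound 3 to compound 4 (0.06 log units; within the scatter).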

Compound 4, half-maximal inhibitory concentration: 152 ug/mL
Estimate against measurement, compound 4: 2.4-fold (0.37 log units) above; the measured number lies below the stated range.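

In this assay, among these compounds, carbamoyl in place of (methanesulfonamido)methyl on this saturated ring carbon, next to the ring oxygen, gives the first readable step at this position that lies beyond the scatter: a 2.1-fold lower number from compound 3 to compound 4 (0.32 log units; beyond the scatter). Against the other two compounds the steps are floors, an at least 2.6-fold lower number from compound 2 to compound 4 (0.42 log units; beyond the scatter) and an at least 2.6-fold lower number from compound 1 to compound 4 (0.42 log units; beyond the scatter), and both also lie beyond the scatter, so compound 4 is the strongest inhibitor of the four shown. Compounds 1 and 2 remain limits rather than numbers: the limit of > 400 ug/mL in this assay, at which 2 of the 4 values shown sit.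

The change removes the saturated chain carbon and exchanges the end group in a single step, and the compounds shown do not separate the two. Also open, as far as these compounds go, is where an aminomethyl group or a carboxylic acid on this ring carbon would fall in this assay.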